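Halogenated benzyl replaces methoxybenzyl on the shared core

The compounds below may be only part of what the source reports. "The series", "measured", "known", "first", "only" and "open" are said of these compounds alone.

Compound 3 `COc1cccc(CNc2ncnc3c2ncn3[C@@H]2O[C@H](CO)[C@@H](O)[C@H]2O)c1` carries a 3-methoxyphenyl on a saturated chain carbon bound to a nitrogen on an aromatic ring. In a functional assay on CCRF-CEM cells (Homo sapiens) for antiproliferative activity, with a stated time of 72 h (a higher number here means a weaker inhibitor, a lower number a stronger inhibitor), compound 3 gives 7600 nM, the second highest of the three numbers recorded. Compound 2 `COc1ccccc1CNc1ncnc2c1ncn2[C@@H]1O[C@H](CO)[C@@H](O)[C@H]1O` gives 3200 nM, and compound 1 `Cc1cccc(CNc2ncnc3c2ncn3[C@@H]2O[C@H](CO)[C@@H](O)[C@H]2O)c1` gives 19100 nM. The measured steps are a 6.0-fold lower number from compound 1 to compound 2 (0.78 log units; beyond the scatter), a 2.5-fold lower number from compound 1 to compound 3 (0.40 log units; beyond the scatter) and a 2.4-fold higher number from compound 2 to compound 3 (0.38 log units; beyond the scatter), each modest. For the measured compounds named here, compound 4 `OC[C@H]1O[C@@H](n2cnc3c(NCc4ccc(F)c(Cl)c4)ncnc32)[C@H](O)[C@@H]1O` differs from compound 3 in one place: 3-chloro-4-fluorophenyl in place of 3-methoxyphenyl on a saturated chain carbon bound to a nitrogen on an aromatic ring No measured step covers a halogenated ring at this position; the measured steps show only that exchanges of the aryl group at this place move the number by modest amounts in either direction. The step from compound 3 to compound 4 is therefore expected to stay modest, with no firm direction. On that basis compound 4 is expected to give about 5000 nM in this assay, within a range of 1500 nM to 20000 nM. This expected step reads a 1.5-fold lower number from compound 3 to compound 4 (0.18 log units; within the scatter).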

Compound 4, half-maximal inhibitory concentration: 3400 nM
Compound 4: the middle estimate sits 1.5-fold (0.17 log units) above what was measured; the measured number falls inside the stated range.
By their numbers in this assay, from the lowest: compounds 2 and 4 (each within the scatter of the next); then compound 3; then compound 1.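

In this assay, a halogenated ring is accepted at this position: the exchange gives a 2.2-fold lower number from compound 3 to compound 4 (0.35 log units; beyond the scatter), and it also gives a 5.6-fold lower number from compound 1 to compound 4 (0.75 log units; beyond the scatter). The earlier compounds had shown lower numbers only with a methoxy-bearing ring relative to the 3-methylphenyl of compound 1, yet the 3-chloro-4-fluorophenyl carries no hydrogen-bond acceptor and still gives a 1.1-fold higher number from compound 2 to compound 4 (0.03 log units; within the scatter), so in this set an oxygen on the ring is not required for a number of this size. No measurement available here accounts for these steps.

The compounds shown do not separate the contribution of the chlorine from that of the fluorine. On these data alone, how a ring bearing an amine or a carboxylic acid, or a longer chain between the nitrogen and the ring, would read remains open.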